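A few compounds are considered here, and "the series" means these few. Any claim that something is new, unique, unknown or untested is made for them only; others in the source may bear on it.

Working notes on a small set of chloropropyl ureas built on a sulfonate ester.

Compound 1 `CCc1ccccc1OS(=O)(=O)c1cccc(NC(=O)NCCCCl)c1` is the starting point. In a functional assay on MCF7 cells (Homo sapiens) for cytotoxicity, read by sulforhodamine B assay, with a stated time of 48 h (a higher number here means a weaker inhibitor, a lower number a stronger inhibitor), compound 1 gives 25000 nM. Compound 2 `CCCc1ccccc1OS(=O)(=O)c1cccc(NC(=O)NCCCCl)c1` carries one extra carbon on the chain; the change (methyl in place of hydrogen on a saturated chain carbon, two bonds along the chain from an aromatic carbon). In this assay compound 2 gives 14000 nM, so the step of a 1.8-fold lower number from compound 1 to compound 2 (0.25 log units; within the scatter) does not rise above the usual spread of repeats.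

Compound 3 `CCc1ccccc1OS(=O)(=O)c1ccc(NC(=O)NCCCCl)cc1` has the same atoms as compound 1 joined differently; how its core differs from the core of compound 1 is not broken down here. In this assay compound 3 gives 15000 nM. Its value and that of compound 2 are within the scatter of each other, and so are its value and that of compound 1, so no order among the three is claimed.

Compound 4 `CCCc1ccccc1OS(=O)(=O)c1ccc(NC(=O)NCCCCl)cc1` is not yet measured. It stands to compound 3 as compound 2 stands to compound 1: the change (methyl in place of hydrogen on a saturated chain carbon, two bonds along the chain from an aromatic carbon), the same change at the same place as before. Within the data shown here, the only guide to its effect is the single earlier step of a 1.8-fold lower number from compound 1 to compound 2 (0.25 log units; within the scatter), which lay within the scatter, so a step of similar size at most is expected, a 1.5-fold lower number from compound 3 to compound 4 (0.18 log units; within the scatter).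

For compound 4 in this assay the expected value is 10000 nM, with the likely range running from 5000 nM to 25000 nM, a range that rests on compound 3 at 15000 nM and on the small earlier step.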

Compound 4, half-maximal inhibitory concentration: 15000 nM
The estimate for compound 4 lay 1.5-fold (0.18 log units) below the measured number; the range from low to high includes it.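

On the core of compound 3, the step from 2-ethylphenyl to 2-propylphenyl gives, in this assay, no change at the digits printed from compound 3 to compound 4 (within the scatter). Set beside the same change on the core of compound 1, the two steps cannot be told apart: the same change on two cores in this assay, a 1.8-fold lower number (0.25 log units; within the scatter) from compound 1 to compound 2 and no change at the digits printed (within the scatter) from compound 3 to compound 4, 1.8-fold (0.25 log units) apart, within the scatter of two such steps. In this assay, then, the change carries from one core to the other without a detectable difference, but neither step rises above the scatter, so what carries over is the lack of a measurable effect rather than a real gain, and two pairs of compounds support no general rule for the series.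

The compounds shown leave open whether any change to this substituent can move the number beyond the scatter, since they span only ethyl and propyl at this place, and a longer chain such as butyl, or an amine or a carboxylic acid at the end of the chain, would test that more severely. They also leave open what the chloropropyl group on the urea contributes, as every compound here carries it and none has a plain propyl chain or a hydroxypropyl chain in its stead.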